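Swapping a Fluorophenoxy Group for Trifluoromethylsulfanyl: Solubility Outlook

The source may hold more compounds than are shown below. What is called first, only, known or untested is meant among the compounds shown, and "the series" means these compounds.

Compound 1 `Cc1noc(-c2nc(C)c3c(c2N)C(=O)N(Cc2ccc(Oc4ccc(F)cc4)cc2)C3=O)n1` has been tested in a physicochemical assay for solubility, using the shake flask method, in simulated intestinal fluid, measured as kinetic solubility, with a stated time of 2 h, at 25 degrees C, at pH 6.5; a higher number here means a more soluble compound, a lower number a less soluble compound. In this assay compound 1 gives 23800 nM. Compound 2 `COc1cccc(CN2C(=O)c3c(C)nc(-c4nc(C)no4)c(N)c3C2=O)c1` has been tested in this assay as well, and compound 2 gives < 5000 nM, which is a limit of the assay and not a number. Among the measured compounds shown here, compound 1 therefore stands as the holder of the only number among the two values shown; the other value is the limit of < 5000 nM in this assay, at which 1 of the 2 values shown sits. For the measured compounds named here, because the two compounds differ in more than one place, no step between them is available, and the two values show only that compound 1 has a number where compound 2 has a limit.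

Compound 3 `Cc1noc(-c2nc(C)c3c(c2N)C(=O)N(Cc2ccc(SC(F)(F)F)cc2)C3=O)n1` has not yet been measured in this assay. It differs from compound 1 in one place: (trifluoromethyl)sulfanyl in place of 4-fluorophenoxy on an aromatic carbon. Going by the values given here, with no measured step to lean on, the step from compound 1 to compound 3 is expected to be small, not beyond the scatter in either direction, as a 1.1-fold higher number from compound 1 to compound 3 (0.02 log units; within the scatter). Compound 3 is accordingly estimated at 25000 nM, with a likely range from 8000 nM to 70000 nM.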

Compound 3, solubility: < 5000 nM
Compound 3: no number, only a limit; the forecaster's own chance of this, stated with the estimate: 15%; middle value at least 5.0-fold (0.69 log units) away from the limit.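

In this assay compound 3 gives < 5000 nM, which is a limit of the assay and not a number. This is the first change in a single place among the compounds shown, and it reveals that the read-out depends on which group sits on this aromatic carbon, para to a large group: putting (trifluoromethyl)sulfanyl in place of 4-fluorophenoxy, with the rest of the molecule unchanged, gives an at least 4.7-fold lower number from compound 1 to compound 3 (0.67 log units; beyond the scatter). The true size of this step remains unknown, as the read-out for compound 3 stops at a limit that now recurs among the compounds shown: the limit of < 5000 nM in this assay, at which 2 of the 3 values shown sit.

The change removes the aromatic ring and the oxygen of 4-fluorophenoxy and brings in sulfur and a trifluoromethyl group all at once, so the compounds shown cannot tell which of these differences goes with the lower read-out. They also leave open how a quite different group at this place, such as an amine or a carboxylic acid, would read in this assay, and whether any such group would rise above compound 1 or fall to the same limit.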